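The compounds below may be only part of what the source reports. "The series", "measured", "known", "first", "only" and "open" are said of these compounds alone.

Among the measured compounds shown here, compound 1 `CN1CCC(CNc2ccc3[nH]nc(-c4cnn(C)c4)c3c2)CC1` stands at the top of the three numbers measured so far in an assay on isolated protein for inhibition of tyrosine-protein kinase receptor UFO (Homo sapiens), with a stated time of 1.5 h (a higher number here means a weaker inhibitor, a lower number a stronger inhibitor), where compound 1 gives 1850000 nM, so it is the weakest inhibitor of the set. Compound 2 `CN1CC[C@@H](Nc2cc3c(-c4cnn(C)c4)n[nH]c3cc2Cl)C1` gives 74000 nM, and compound 3 `Cc1ccc2nc(C(F)(F)F)cc(N3CCNCC3)c2c1` gives 204000 nM; both lie well apart from compound 1, beyond the usual scatter. Compound 4 `Cn1cc(-c2n[nH]c3ccc(N[C@H]4CCNC4)cc23)cn1` has not yet been measured. It differs from compound 1 in one place: pyrrolidin-3-yl in place of (1-methylpiperidin-4-yl)methyl on a nitrogen on an aromatic ring. A step toward a lower number, that is a stronger inhibitor, is expected, a 6.2-fold lower number from compound 1 to compound 4 (0.79 log units; beyond the scatter), because compound 2, which also carries an amine on a five-membered ring attached to the shared core, gives 74000 nM. For compound 4 the estimate in this assay is 300000 nM, with a likely range from 60000 nM to 1500000 nM.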

Compound 4, half-maximal inhibitory concentration: 239000 nM
Compound 4: middle estimate off by 1.3-fold (0.10 log units), on the high side; measured number inside the range.
By their numbers in this assay, from the lowest: compound 2; then compounds 3 and 4 (each within the scatter of the next); then compound 1.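

Among the compounds shown here, on the nitrogen on an aromatic ring, the group matters: in this assay, pyrrolidin-3-yl in place of (1-methylpiperidin-4-yl)methyl gives a 7.7-fold lower number from compound 1 to compound 4 (0.89 log units; beyond the scatter) on the shared core, the first comparison in this set that changes one place only. This single change shrinks the group, adds a hydrogen-bond donor and brings in a defined stereocentre, so several features shift together. Nothing available separates their contributions or explains the step.

Going by these compounds, whether the mirror-image pyrrolidin-3-yl, an azetidine ring or an open-chain amine on that nitrogen would lower the number further remains open.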